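Cyano-to-bromo swap on the aryl thiazolylidene hydrazide series

A few compounds are considered here, and "the series" means these few. Any claim that something is new, unique, unknown or untested is made for them only; others in the source may bear on it.

The series shares a thiazolylidene acylhydrazide core carrying a phenyl group and a para-substituted aryl ring. Compound 1 `N#Cc1ccc(-c2cs/c(=N/NC(=O)CSc3ncccn3)n2-c2ccccc2)cc1` was tested in a functional assay on C6 cells (Rattus norvegicus) for cytotoxicity, read by MTT assay, with a stated time of 24 h (a lower number here means a stronger inhibitor, a higher number a weaker inhibitor), but for compound 1 the reported entry is "not determined" (no result reported), so compound 1 stands without a number. For the measured compounds named here, compound 2 `Cc1nnc(SCC(=O)N/N=c2/scc(-c3ccc(Cl)cc3)n2-c2ccccc2)s1` is the only measured member: in this assay compound 2 gives 28 ug/mL. Compound 3 `O=C(CSc1ncccn1)N/N=c1/scc(-c2ccc(Br)cc2)n1-c1ccccc1` is still to be measured in this assay. Compound 3 differs from compound 1 by bromo in place of cyano on an aromatic carbon, the change sitting on an aromatic carbon of a six-membered aromatic ring of carbon only, para to a large group. Going by the values given here, with no step measured between any pair, no direction or size can be read from the data; the expectation is a value near compound 2, within the usual scatter. Compound 3 is therefore expected to give about 30 ug/mL in this assay, with a range from 12 ug/mL to 75 ug/mL.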

Compound 3, half-maximal inhibitory concentration: > 200 ug/mL
Compound 3 gave a limit, no number; the forecaster's own chance of this, stated with the estimate: 15%; middle value at least 6.6-fold (0.82 log units) from the limit.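

In this assay, for the compounds shown here, compound 3 gives > 200 ug/mL as a limit and compound 1 has no number, so no step between compound 1 and compound 3 can be read. As far as these compounds go, what the swap from 4-cyanophenyl to 4-bromophenyl does in this assay on the shared core stays open.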